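A hydroxy for a methoxy on the oxazepane ring

The source may report more compounds than this note shows. Statements on the series, on what has been measured and on what is new or still open speak of the compounds shown alone.

Compound 1 `COC1COCCN(S(=O)(=O)c2cc(C(=O)Nc3ccc(F)c(Cl)c3)ccc2F)C1` and compound 2 `CC(O)C1CCCCN(S(=O)(=O)c2cc(C(=O)Nc3ccc(F)c(Cl)c3)ccc2F)C1` share a core and differ only in the ring carried on the sulfonyl sulfur. Among the compounds with values here, in an ADME assay on HepG2 2.2.15 cells (Homo sapiens) for cytotoxicity, read by luminescence, with a stated time of 3 days (a lower number here means that less compound is tolerated, a higher number that more compound is tolerated), compound 1 gives 8700 nM, the highest of the two numbers so far, and compound 2 gives 2600 nM. Within the data shown here, the single measured step, a 3.3-fold lower number from compound 1 to compound 2 (0.52 log units; beyond the scatter), exchanges the whole ring and so speaks only indirectly to the change now considered. Compound 3 `O=C(Nc1ccc(F)c(Cl)c1)c1ccc(F)c(S(=O)(=O)N2CCOC[C@@H](O)C2)c1` keeps the ring type of compound 1 and differs from it in one place: 6-hydroxy-1,4-oxazepan-4-yl in place of 6-methoxy-1,4-oxazepan-4-yl on a sulfonyl sulfur. Among the measured compounds shown here, no measured pair shows this kind of exchange, so the expectation rests on the small extent of the change and on the modest spread between compound 1 and compound 2 in this assay. A step no larger than the usual scatter is expected, with a slight lean toward a lower number, so a step of a 1.2-fold lower number from compound 1 to compound 3 (0.09 log units; within the scatter) is expected. Compound 3 is therefore estimated at 7000 nM in this assay, within 3000 nM to 20000 nM.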

Compound 3, half-maximal cytotoxic concentration: 14000 nM
Compound 3: the middle estimate sits 2.0-fold (0.30 log units) below what was measured; low and high end bracket the measured number.
By their numbers in this assay, from the lowest: compound 2; then compounds 1 and 3 (each within the scatter of the next).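

On the sulfonyl sulfur, 6-hydroxy-1,4-oxazepan-4-yl in place of 6-methoxy-1,4-oxazepan-4-yl gives a 1.6-fold higher number from compound 1 to compound 3 (0.21 log units; within the scatter) in this assay, so the exchange adds a hydrogen-bond donor to the ring without a step that can be told from the scatter. Against 3-(1-hydroxyethyl)azepan-1-yl, the same group gives a 5.4-fold higher number from compound 2 to compound 3 (0.73 log units; beyond the scatter), which leaves compound 2 with the lowest number of the three, its steps to compound 1 and compound 3 both being beyond the scatter, and shows that a hydroxy group, present in both compound 2 and compound 3, does not by itself go with the lower number. Nothing available explains either step.

As far as these compounds go, whether the opposite configuration at the defined stereocentre of the 6-hydroxy-1,4-oxazepan-4-yl group would give a number close to that of compound 3 remains open. So does what an amine or a carboxylic acid would do in place of the hydroxy group on this ring, and whether the azepane ring or its 1-hydroxyethyl chain accounts for the step to compound 2.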